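Phenyl in Place of 2,5-Dimethoxyphenyl

The source may hold more compounds than are shown below. What is called first, only, known or untested is meant among the compounds shown, and "the series" means these compounds.

Of the compounds shown here, three sharing a similar core have been tested in an ADME assay on HT-29 cells (Homo sapiens) for cytotoxicity, read by MTT assay, with a stated time of 72 h; on this read-out higher numbers stand for weaker inhibition and lower numbers for stronger inhibition. In this test, compound 1 `COc1ccc(OC)c(C2=C(c3cc(OC)c(OC)c(OC)c3)C(=O)CC2O[SiH2]C(C)(C)C)c1` gives 5 ug/mL. Compound 3 `COc1ccc(C2=C(c3cc(OC)c(OC)c(OC)c3)C(=O)C(O[SiH2]C(C)(C)C)C2)cc1OC(C)C` gives 9 ug/mL, which lies within the usual scatter of the value for compound 1, so the two cannot be told apart. In this assay, compound 2 `COc1cc(C2=C(c3cc(C)c(OC)c(C)c3)C(O)CC2=O)cc(OC)c1OC` has no exact number and is reported only as a limit, > 100 ug/mL. For the measured compounds named here, compound 1 therefore stands level with compound 3, and these are the only two compounds with a measured number.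

The next compound to be measured is compound 4 `COc1cc(C2=C(c3ccccc3)C(O[SiH2]C(C)(C)C)CC2=O)cc(OC)c1OC`. It differs from compound 1 in one place: phenyl in place of 2,5-dimethoxyphenyl on a double-bonded ring carbon.

Going by the values given here, no tested pair differs in only one place, so the evidence for the size of this change is thin. Compound 3 also carries a different arrangement of its rings from compound 1, and compound 3 still gives 9 ug/mL. A modest rise towards weaker inhibition in this assay is expected, with an estimated step of a 2.4-fold higher number from compound 1 to compound 4 (0.38 log units; beyond the scatter). For compound 4 the estimated value is 12 ug/mL, with an expected range from 3 ug/mL to 50 ug/mL.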

Compound 4, half-maximal inhibitory concentration: > 100 ug/mL
Compound 4: a limit, no number (the forecaster's own chance of this, stated with the estimate: 10%); middle value at least 8.3-fold (0.92 log units) from the limit.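

This is the first pair shown that differs in only one place, and it shows that this position matters: phenyl in place of 2,5-dimethoxyphenyl on a double-bonded ring carbon gives an at least 20-fold higher number from compound 1 to compound 4 (1.30 log units; beyond the scatter) in this assay. The value of compound 4, > 100 ug/mL, is a limit and not a number, so the step has a floor but no known upper end, and the reading sits where one other compound shown also sits: the limit of > 100 ug/mL in this assay, at which 2 of the 4 values shown sit. The group that leaves carries 2 hydrogen-bond acceptors and the phenyl that enters carries 0, so the measured inhibition of compound 1 does not survive on the rest of the molecule alone, and something in the 2,5-dimethoxyphenyl group is needed for it.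

Which part of that group counts remains open, including whether a phenyl with a single methoxy group would be enough. As far as these compounds go, it is also open whether a different group at this position, such as an amine or a carboxylic acid, would give a measurable value in this assay.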